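The source may report more compounds than this note shows. Statements on the series, on what has been measured and on what is new or still open speak of the compounds shown alone.

Measured so far in a functional assay on HT-29 cells (Homo sapiens) for antiproliferative activity, read by MTT assay, with a stated time of 48 h; a lower number here means a stronger inhibitor, a higher number a weaker inhibitor:
- compound 1 `COc1cc(N/C=C\C(=O)c2cn(-c3ccccc3)nc2-c2ccccc2)cc(OC)c1OC`: 9800 nM
- compound 2 `O=C(/C=C\Nc1ccc(O)cc1)c1cn(-c2ccccc2)nc1-c1ccc(F)cc1`: 1900 nM
- compound 3 `COc1ccc(N/C=C\C(=O)c2cn(-c3ccccc3)nc2-c2ccc(F)cc2)cc1`: 3200 nM

Compound 1 stands highest of the three numbers in this assay; the nearest is compound 3, the furthest compound 2, both gaps beyond the scatter. Going by the values given here, the only single-place step among the measured compounds, a 1.7-fold higher number from compound 2 to compound 3 (0.23 log units; within the scatter), concerns the oxygen substituent on the anilino ring and lies within the scatter; it does not touch the ring changed here.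

Compound 4 `COc1cc(N/C=C\C(=O)c2cn(-c3ccccc3)nc2-c2ccc(Cl)cc2)cc(OC)c1OC` differs from compound 1 by chloro in place of hydrogen on an aromatic carbon, i.e. phenyl to 4-chlorophenyl on the shared core. Among the compounds with values here, no measured step bears directly on this change. Compounds 2 and 3 both carry a halogen on that ring and give lower numbers than compound 1, but they also differ on the anilino ring, so that comparison is not a clean step. A modest move to a lower number is expected, a 2.0-fold lower number from compound 1 to compound 4 (0.29 log units; within the scatter), with wide uncertainty. Compound 4 is estimated at 5000 nM in this assay, range 1500 nM to 15000 nM.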

Compound 4, half-maximal inhibitory concentration: 12700 nM
Beside the measured number, compound 4's estimate is 2.5-fold (0.40 log units) below it; measured number inside the range.
By their numbers in this assay, from the lowest: compounds 2 and 3 (each within the scatter of the next); then compounds 1 and 4 (each within the scatter of the next).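

In this assay, going by these compounds alone, the first single-place reading at this position gives a 1.3-fold higher number from compound 1 to compound 4 (0.11 log units; within the scatter) and lies within the scatter. On the core of compound 1, phenyl and 4-chlorophenyl therefore cannot be told apart, and chloro at this place, para to a large group, shows no measurable effect in this assay. Nothing on hand offers an explanation for this flat step.

Going by these compounds, it remains open whether a different group at this place, such as a nitrile, an amine or a carboxylic acid, would move the number beyond the scatter. Also open, on these data alone, is whether the same chloro change reads alike when the rest of the molecule is that of compound 2 or compound 3.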